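The source may report more compounds than this note shows. Statements on the series, on what has been measured and on what is new or still open speak of the compounds shown alone.

In an in vivo ADME assay on the whole organism (strain 129/SvEvBrd x C57BL/6) for pharmacokinetics, with Mus musculus as the target (a lower number here means that a smaller share of the oral dose reaches the circulation, a higher number that a larger share of the oral dose reaches the circulation), three compounds have been measured so far. Compound 1 (`CC(=O)c1cccc([C@@H](O)[C@H](O)[C@H](O)CO)n1`) gives 88%, compound 2 (`CC(=O)c1nc([C@@H](O)[C@H](O)[C@H](O)CO)c(C)[nH]1`) gives 11%, and compound 3 (`CN(C)C(=O)c1nc([C@@H](O)[C@H](O)[C@H](O)CO)c[nH]1`) gives 5%. Compound 3 thus sits with compound 2 at the low end of this small set. Those two lie within the scatter of each other, and compound 3 lies well beyond the scatter from compound 1.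

The next compound, compound 4 (`OC[C@@H](O)[C@@H](O)[C@H](O)c1c[nH]c(-c2ncon2)n1`), differs from compound 3 in one group: 1,2,4-oxadiazol-3-yl in place of dimethylcarbamoyl on an aromatic carbon. Here 1,2,4-oxadiazol-3-yl takes the place of dimethylcarbamoyl on an aromatic carbon of a five-membered aromatic ring with 2 nitrogen, between two ring nitrogen atoms. Among the measured compounds shown here, no measured pair differs in one place, so the data offer no direct precedent for this exchange.

The closest guide is compound 2 at 11%, which shares that ring with compound 3 and also stays low. The high value of compound 1, 88%, belongs to a different core and says little about this change. Only a modest upward move is therefore expected, an estimated a number 15 percentage points higher from compound 3 to compound 4 (beyond the scatter). The estimated value for compound 4 is 20%, within an expected range of 5% to 50%.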

Compound 4, oral bioavailability: 5%
Beside the measured number, compound 4's estimate is 15 percentage points above it; the measured number falls inside the stated range.
By their numbers in this assay, from the lowest: compounds 3, 4 and 2 (each within the scatter of the next); then compound 1.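

In this assay, among the compounds shown here, putting 1,2,4-oxadiazol-3-yl in place of dimethylcarbamoyl on an aromatic carbon, between two ring nitrogen atoms, gives no change at the digits printed from compound 3 to compound 4 (within the scatter) and provides the first direct reading of a single exchange at this position. Dimethylcarbamoyl has no ring and 1 hydrogen-bond acceptor, while 1,2,4-oxadiazol-3-yl has one five-membered aromatic ring with 3 hetero atoms and 3 hydrogen-bond acceptors, yet at 5 heavy atoms each the two groups read alike here, so this particular exchange does not separate the two compounds. Nothing measured in the material at hand accounts for this result.

On these data alone, whether a group of another kind at this position, such as an amine or a carboxylic acid, would read differently from compound 3 at 5% in this assay remains open. Also unresolved is whether a single exchange elsewhere on the shared core, for instance in the group of 8 heavy atoms, would move the number more than either group at this position has.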